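Ethynyl Replacing Allyl: Expected Tolerance of Compound 4

The source may report more compounds than this note shows. Statements on the series, on what has been measured and on what is new or still open speak of the compounds shown alone.

Compound 3 `C=CC[C@]1(CO)S[C@@H](n2cc(C)c(=O)[nH]c2=O)C[C@@H]1O` stands only at a limit in an ADME assay on MT4 cells (Homo sapiens) for cytotoxicity, read by MTT assay, with a stated time of 4 days; a higher number here means that more compound is tolerated, a lower number that less compound is tolerated: compound 3 gives > 100000 nM, which is a limit of the assay and not a number. Compound 1 `Cc1cn([C@H]2C[C@H](O)[C@](CO)(Sc3ccccc3)S2)c(=O)[nH]c1=O` also gives a limit, > 100000 nM. Compound 2 `CO[C@]1(CO)S[C@@H](n2cc(C)c(=O)[nH]c2=O)C[C@@H]1O` likewise gives a limit, > 100000 nM. Because the limit of > 100000 nM in this assay, at which 3 of the 3 values shown sit, none of the steps among them can be read: a step that the two limits leave unreadable from compound 1 to compound 2, a step that the two limits leave unreadable from compound 1 to compound 3 and a step that the two limits leave unreadable from compound 2 to compound 3 all have no readable size. Compound 4 `C#C[C@]1(CO)S[C@@H](n2cc(C)c(=O)[nH]c2=O)C[C@@H]1O` differs from compound 3 by ethynyl in place of allyl on a saturated ring carbon. With no readable step to draw on, no change beyond the scatter is expected, and the step of a number no higher from compound 3 to compound 4 (the limit leaves the size open) is expected to be flat. Compound 4 is therefore expected to give 100000 nM in this assay, within 60000 nM to 300000 nM, most likely again as a limit.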

Compound 4, half-maximal cytotoxic concentration: > 100000 nM
Compound 4: a limit, no number; the forecaster's own chance of this, stated with the estimate: 85%; the middle value sits exactly at the limit.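

The steps linking compound 4 with compound 1, compound 2 and compound 3 in this assay cannot be read, because all four compounds share one limit: the limit of > 100000 nM in this assay, at which 4 of the 4 values shown sit.

The compounds shown leave open whether phenylsulfanyl, methoxy, allyl or ethynyl differ at all in how much compound is tolerated.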